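From compound 3 to compound 4: isopropoxy enters

This account rests on a few compounds, and the source may have more. Where it says the series, first, only, none or still open, it means among the compounds named here.

Compound 1 `CC(C)Oc1ccc(C(O)(c2ccc(Cl)cc2)c2cccnc2)cc1`: 56600 nM.
Compound 2 `NC(=O)c1cccc(C(O)(c2ccc(C(F)(F)F)cc2)c2cccnc2)c1`: > 100000 nM.
Compound 3 `OC(c1ccc(C(F)(F)F)cc1)(c1cccnc1)c1ccc(Cl)cc1F`: > 100000 nM.

These values come from an ADME assay on L6 cells (Rattus norvegicus) for cytotoxicity, read by resazurin assay, with a stated time of 72 h; on this read-out higher numbers stand for weaker inhibition and lower numbers for stronger inhibition. Compound 3 has no number here, only a limit, > 100000 nM. Compound 2 also has only a limit, > 100000 nM. For the measured compounds named here, the series therefore offers (the limit of > 100000 nM in this assay, at which 2 of the 3 values shown sit), and the one measured step between close relatives, a step that the two limits leave unreadable from compound 2 to compound 3, has no readable size and sets no scale for what follows.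

Compound 4 `CC(C)Oc1ccc(C(O)(c2cccnc2)c2ccc(Cl)cc2F)cc1` departs from compound 3 by one change: isopropoxy in place of trifluoromethyl on an aromatic carbon. Going by the values given here, no measured step covers this exchange. The nearest guide is compound 1, which also carries isopropoxy and reads as a number, 56600 nM. On that single value, compound 4 is expected to fall within the measurable range, on the side of stronger inhibition relative to the limit of compound 3, although it may yet reach the limit itself. The expected change is an at least 2.0-fold lower number from compound 3 to compound 4 (0.30 log units; that floor lies within the scatter), and its size stays uncertain since it starts from a limit. For compound 4 the estimate is 50000 nM, with an expected range from 20000 nM to 100000 nM.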

Compound 4, half-maximal inhibitory concentration in the L6 assay: 56000 nM
For compound 4 the middle estimate is 1.1-fold (0.05 log units) below the measured one, within the range that was stated.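

From the compounds shown here alone, in the L6 assay, isopropoxy in place of trifluoromethyl on an aromatic carbon gives compound 4 a measured number where its partner had none, a change of an at least 1.7-fold lower number from compound 3 to compound 4 (0.25 log units; that floor lies within the scatter), and the true size stays open since that step starts from a limit: the limit of > 100000 nM in the L6 assay, at which 2 of the 4 values shown sit. Fluoro in place of hydrogen on an aromatic carbon makes no readable difference, with a 1.0-fold lower number from compound 1 to compound 4 (0.00 log units; within the scatter), so the two isopropoxy compounds read alike with or without the fluoro. In a physicochemical assay for solubility, read by nephelometry, measured as kinetic solubility, at pH 6.5 (on this read-out higher numbers stand for higher solubility and lower numbers for lower solubility), the step for the isopropoxy exchange cannot be read, since compound 3 sits at a limit: the limit of < 1.6 ug/mL in the physicochemical assay, at which 1 of the 2 values shown sits. In the physicochemical assay compound 3 gives < 1.6 ug/mL, which is a limit and not a number.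

The compounds shown leave open whether the measurable cytotoxicity belongs to isopropoxy itself or would also appear with another group on this aromatic carbon, such as a methoxy, a longer alkoxy chain or an amine. Going by these compounds, in the physicochemical assay compound 4 gives 1.6 ug/mL, and how far a carboxylic acid or an amine at the same place would move that value also remains open.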